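A few compounds are considered here, and "the series" means these few. Any claim that something is new, unique, unknown or untested is made for them only; others in the source may bear on it.

Measured so far:
compound 1, `Cc1cccc(/C=C2\CCC/C(=C\c3ccccc3)C2=O)c1`, 47.9%
compound 2, `O=C1/C(=C/c2ccccc2)CCC/C1=C\c1cccc(Br)c1`, 27.2%
compound 3, `O=C1/C(=C/c2ccccc2)CCC/C1=C\c1cccc(O)c1`, 65.1%

In an assay on isolated protein for inhibition of Alpha glucosidase (Homo sapiens), with stated times of 5 min and 15 min, tested at 50 uM (a higher number here means more inhibition at the concentration tested (going by the name of the read-out), a lower number less inhibition), compound 3 stands highest of the three: the step of a number 17.2 percentage points higher from compound 1 to compound 3 (beyond the scatter) and the step of a number 37.9 percentage points higher from compound 2 to compound 3 (beyond the scatter) both lie beyond the scatter, so compound 3 gives the highest number of the measured set.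

Compound 4, `O=C1/C(=C/c2ccccc2)CCC/C1=C\c1ccc(F)cc1`, differs from compound 3 in one respect: 4-fluorophenyl in place of 3-hydroxyphenyl on a double-bonded chain carbon bound to a double-bonded ring carbon. Going by the values given here, two measured steps bear on this, the ones in which the hydroxy group enters or leaves the aromatic carbon: a number 17.2 percentage points higher from compound 1 to compound 3 (beyond the scatter) and a number 37.9 percentage points higher from compound 2 to compound 3 (beyond the scatter). In both, the compound carrying the hydroxy gives the larger number, by a modest and by a large margin. The third step, a number 20.7 percentage points lower from compound 1 to compound 2 (beyond the scatter), shows that bromo in place of methyl lowered the number. Among the compounds with values here, no compound carrying fluoro has been measured, so what fluoro alone does is not known. Losing the hydroxy therefore points to a drop beyond the scatter, and the expected step is a number 30.1 percentage points lower from compound 3 to compound 4 (beyond the scatter). Compound 4 is estimated at 35%, with a range from 15% to 55%.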

Compound 4, a percentage reported as inhibition, at one concentration (the size of the read-out at that concentration, not a potency): 34%
The estimate for compound 4 lay 1 percentage points above the measured number, within the range that was stated.
By their numbers in this assay, from the lowest: compounds 2 and 4 (each within the scatter of the next); then compound 1; then compound 3.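

In this assay, the step of a number 31.1 percentage points lower from compound 3 to compound 4 (beyond the scatter) shows that a ring with fluoro instead of hydroxy does not hold the higher number, so compound 3 remains above every other compound here. The two other new steps place fluoro among the earlier groups: a number 6.8 percentage points higher from compound 2 to compound 4 (within the scatter), so compound 4 and compound 2 cannot be told apart, while a number 13.9 percentage points lower from compound 1 to compound 4 (beyond the scatter) puts compound 4 clearly under the methyl compound. Nothing available explains why the hydroxy compound stands apart from the others.

As far as these compounds go, this change swaps the group and also moves it, from 3-hydroxyphenyl to 4-fluorophenyl, so the share of each remains open, and a 3-fluorophenyl or 4-hydroxyphenyl compound would help separate them. Also open, from the compounds shown here alone, is how an amino or methoxy group on this ring would compare with hydroxy.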